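The source may report more compounds than this note shows. Statements on the series, on what has been measured and on what is new or still open speak of the compounds shown alone.

Measured compounds in a functional assay on HT-29 cells (Homo sapiens) for cytotoxicity, read by MTT assay, with a stated time of 72 h; on this read-out higher numbers stand for weaker inhibition and lower numbers for stronger inhibition:
- compound 1 `COc1cc2c(Oc3ccc(NC(=O)c4cn(-c5ccccc5)nn4)cc3F)ccnc2cc1OCCCN1CCCC1`: 180 nM
- compound 2 `COc1cc2c(Oc3ccc(NC(=O)c4cn(-c5ccccc5C)nn4)cc3F)ccnc2cc1OCCCN1CCCC1`: 1200 nM
- compound 3 `COc1cc2c(Oc3ccc(NC(=O)c4cn(-c5ccccc5C)nn4)cc3F)ccnc2cc1OCCCN1CCCCC1`: 1340 nM

Compound 3 gives the highest number of the three in this assay; compound 2 sits within the scatter of it (a 1.1-fold higher number from compound 2 to compound 3 (0.05 log units; within the scatter)), while compound 1 lies well apart, with a 6.7-fold higher number from compound 1 to compound 2 (0.82 log units; beyond the scatter) accounting for almost all of that gap.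

Compound 4 `COc1cc2c(Oc3ccc(NC(=O)c4cn(-c5c(Cl)cccc5Cl)nn4)cc3F)ccnc2cc1OCCCN1CCCCC1` is not yet measured. It differs from compound 3 by 2,6-dichlorophenyl in place of 2-methylphenyl on an aromatic nitrogen. Among the measured compounds shown here, the only measured step that bears on this position is the one from compound 1 to compound 2, where methyl in place of hydrogen on the aromatic carbon gave a modest rise in the number. For the measured compounds named here, no measured pair shows chlorine at this ring, nor substitution on both flanking carbons of the phenyl, so the size of the new step is uncertain. Given that substitution here has so far only raised the number, compound 4 is expected to land at or somewhat above compound 3, with the step of a 1.5-fold higher number from compound 3 to compound 4 (0.17 log units; within the scatter) plausibly within the scatter.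

Estimate for compound 4 in this assay: 2000 nM, range 600 nM to 7000 nM.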

Compound 4, half-maximal inhibitory concentration: 240 nM
Estimate against measurement, compound 4: 8.3-fold (0.92 log units) above; the whole stated range lies above it.
By their numbers in this assay, from the lowest: compounds 1 and 4 (each within the scatter of the next); then compounds 2 and 3 (each within the scatter of the next).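

In this assay, changing the substituents on the phenyl group carried by the aromatic nitrogen does not move the number in one direction only: methyl in place of hydrogen gave a 6.7-fold higher number from compound 1 to compound 2 (0.82 log units; beyond the scatter), whereas 2,6-dichlorophenyl in place of 2-methylphenyl gave a 5.6-fold lower number from compound 3 to compound 4 (0.75 log units; beyond the scatter). The outcome at this position therefore depends on which substituents are present, and a substituted phenyl here is compatible with the value of compound 4, 240 nM. Nothing available on these compounds accounts for the difference between the two groups.

Still open, going by these compounds, is whether the lower number follows from the chlorine atoms or from the presence of two substituents, which 2-chlorophenyl and 2,6-dimethylphenyl groups could separate. Also open, on these data alone, is whether the same step would appear with pyrrolidin-1-yl in place of piperidin-1-yl on the side chain.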